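The compounds below may be only part of what the source reports. "The series", "measured", "known", "first", "only" and "open" are said of these compounds alone.

Measured so far in a functional assay on FM3A cells (Mus musculus) for inhibition, read by cell counting, with a stated time of 2 days; on this read-out higher numbers stand for weaker inhibition and lower numbers for stronger inhibition:
compound 1 `C=C(Br)C(=O)Nc1cccc(-c2cn3nc(-c4ccc(F)cc4)sc3n2)c1` gives 610 nM
compound 2 `COc1ccc(-c2nn3cc(-c4cccc(N)c4)nc3s2)cc1OC` gives 13000 nM
compound 3 `C=C(Br)C(=O)Nc1cccc(-c2cn3nc(-c4ccc(C)cc4)sc3n2)c1` gives 1200 nM

Compound 3 stands second highest of these three numbers; compound 1 sits nearest, a step within the scatter, while compound 2 sits far higher, beyond it. Going by the values given here, the only single-point step measured runs a 2.0-fold higher number from compound 1 to compound 3 (0.29 log units; within the scatter), so exchanging one small group on the outer aromatic ring barely moved the number. Compound 4 `C=C(Br)C(=O)Nc1cccc(-c2cn3nc(-c4ccc(OC)c(OC)c4)sc3n2)c1` arises from compound 3 by 3,4-dimethoxyphenyl in place of 4-methylphenyl on an aromatic carbon. Among the compounds with values here, no measured step covers this change directly; compound 2 carries the same 3,4-dimethoxyphenyl but also a plain amine instead of the amide, so its weak value cannot be assigned to either part alone. The expected step is therefore a 1.3-fold higher number from compound 3 to compound 4 (0.10 log units; within the scatter), near no change. Compound 4 is estimated at 1500 nM, ranging from 500 nM to 5000 nM.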

Compound 4, half-maximal inhibitory concentration: 110 nM
Beside the measured number, compound 4's estimate is 14-fold (1.13 log units) above it, outside the stated range (below it).
By their numbers in this assay, from the lowest: compound 4; then compounds 1 and 3 (each within the scatter of the next); then compound 2.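

In this assay, this position on the five-membered ring proves sensitive to the group it carries: 3,4-dimethoxyphenyl in place of 4-methylphenyl gives a large drop (an 11-fold lower number from compound 3 to compound 4 (1.04 log units; beyond the scatter)), and in place of 4-fluorophenyl a modest one (a 5.5-fold lower number from compound 1 to compound 4 (0.74 log units; beyond the scatter)), whereas methyl for fluoro stayed within the scatter. With 3,4-dimethoxyphenyl held constant, the (1-bromoethenyl)carbonyl on the nitrogen also matters greatly (a 120-fold lower number from compound 2 to compound 4 (2.07 log units; beyond the scatter)). No measured evidence here explains either effect.

As far as these compounds go, whether a single methoxy group would suffice remains open. So does how a hydroxyl or an amine on that outer ring would compare.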